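Swapping an Anilide Ring for an Acylated Piperidine

The source may report more compounds than this note shows. Statements on the series, on what has been measured and on what is new or still open speak of the compounds shown alone.

Of the compounds shown here, three sharing one core have been measured in a functional assay on HCC827 cells (Homo sapiens) for antiproliferative activity, read by MTT assay, with a stated time of 72 h; a higher number here means a weaker inhibitor, a lower number a stronger inhibitor. Compound 1 `CN1CCN(c2ccc(Nc3ncc4nc(Nc5ccc(F)cc5)n([C@H]5CCCC(NC(=O)OC(C)(C)C)C5)c4n3)cc2)CC1` gives 120 nM, compound 2 `CN1CCN(c2ccc(Nc3ncc4nc(Nc5ccc(F)cc5)n(-c5cccc(NC(=O)CO)c5)c4n3)cc2)CC1` gives 7.5 nM, and compound 3 `CN1CCN(c2ccc(Nc3ncc4nc(Nc5ccccc5)n([C@H]5CCN(S(C)(=O)=O)C5)c4n3)cc2)CC1` gives 17 nM. Compound 2 thus has the lowest number of the three, and its distance to each of the other two is beyond the usual scatter, so it is the strongest inhibitor among them.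

Compound 4 `CN1CCN(c2ccc(Nc3ncc4nc(Nc5ccc(F)cc5)n([C@@H]5CCCN(C(=O)CO)C5)c4n3)cc2)CC1` is not yet measured. It differs from compound 2 at one point: 1-((hydroxymethyl)carbonyl)piperidin-3-yl in place of 3-(((hydroxymethyl)carbonyl)amino)phenyl on an aromatic nitrogen. For the measured compounds named here, no directly comparable pair among the measured compounds shows what this kind of exchange does. The two measured compounds that carry a non-aromatic ring at the same position, compound 1 with 120 nM and compound 3 with 17 nM, both sit higher than compound 2, which suggests a modest loss rather than a gain. Compound 4 is therefore expected to give 20 nM in this assay, within a range of 7 nM to 60 nM. The step from compound 2 to compound 4 is estimated at a 2.7-fold higher number from compound 2 to compound 4 (0.43 log units; beyond the scatter), a small weakening that may not clearly exceed the scatter.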

Compound 4, half-maximal inhibitory concentration: 66 nM
Compound 4: the middle estimate sits 3.3-fold (0.52 log units) below what was measured; measured number outside the range, above it.
By their numbers in this assay, from the lowest: compound 2; then compound 3; then compounds 4 and 1 (each within the scatter of the next).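

Exchanging 3-(((hydroxymethyl)carbonyl)amino)phenyl for 1-((hydroxymethyl)carbonyl)piperidin-3-yl on the aromatic nitrogen gives an 8.8-fold higher number from compound 2 to compound 4 (0.94 log units; beyond the scatter) in this assay, the only direct reading of this exchange among the compounds shown. The hydroxymethyl carbonyl unit and the rest of the molecule stay the same, so the change in the group that carries this unit is enough to weaken the compound in this assay. That change has several parts at once, as the entering group has a non-aromatic ring with a hetero atom, 1 hydrogen-bond donor instead of 2, and a defined stereocentre, and no accompanying measurement separates them or explains the loss.

Going by these compounds, it remains open which of these parts accounts for the step, and whether the opposite configuration at the stereocentre would behave the same way. On these data alone, it is also open how the piperidine would fare with a free ring amine or a longer hydroxypropanoyl chain.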